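Para-substituent change on the benzamide series, cytotoxicity notes

The compounds below may be only part of what the source reports. "The series", "measured", "known", "first", "only" and "open" are said of these compounds alone.

The series shares one core, carried unchanged by compound 1 `O=C(Nc1cccc(-c2nc3ccccc3[nH]2)c1)C1CCCCC1`, compound 2 `COc1ccc(C(=O)Nc2cccc(-c3nc4ccccc4[nH]3)c2)cc1` and compound 3 `O=C(Nc1cccc(-c2nc3ccccc3[nH]2)c1)c1ccc(F)cc1`. In an ADME assay on NIH3T3 cells (Mus musculus) for cytotoxicity, read by resazurin assay, with a stated time of 48 h (on this read-out lower numbers stand for stronger inhibition and higher numbers for weaker inhibition), compound 1 gives 22200 nM. Within the data shown here, compound 2 has no number in this assay; the entry for compound 2 reads "not determined" (no result reported), so compound 2 stands nowhere on the measured scale and no step from compound 1 to compound 2 can be stated.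

Compound 3 differs from compound 2 by a single change: fluoro in place of methoxy on an aromatic carbon, para to a large group, or read one bond further out, 4-methoxyphenyl to 4-fluorophenyl. Among the measured compounds shown here, with no measured step between compounds to lean on, the only anchor is compound 1 at 22200 nM. For this small exchange on the outer ring no step beyond the usual scatter is expected in this assay, in either direction. Compound 3 is therefore expected to give about 25000 nM, within a range of 8000 nM to 80000 nM, and a limit rather than a number is a real possibility.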

Compound 3, half-maximal inhibitory concentration: 15400 nM
Compound 3: middle estimate off by 1.6-fold (0.21 log units), on the high side; the measured number falls inside the stated range.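

In this assay, among these compounds, the swap of cyclohexyl for 4-fluorophenyl on the carbonyl carbon gives a 1.4-fold lower number from compound 1 to compound 3 (0.16 log units; within the scatter) and thus provides the first readable step, showing that at this position the two groups cannot be told apart on this read-out. The exchange of methoxy for fluoro on the outer ring, the change that links compound 2 to compound 3, still cannot be read, as compound 2 has no number; the new value therefore says nothing about the para-substituent itself and speaks only to the replacement of cyclohexyl by the fluorinated aromatic ring. No supporting measurement bears on why compound 1 and compound 3 sit so close together.

Going by these compounds, one step within the scatter gives no trend, so it remains open whether a group of a different kind on the carbonyl carbon, such as an amine, a carboxylic acid or a longer chain, would shift the number in this assay beyond the scatter. On these data alone, on the outer ring, it also remains open how a 4-aminophenyl or a 4-carboxyphenyl would compare with the 4-fluorophenyl of compound 3.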